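The compounds below may be only part of what the source reports. "The series", "measured", "known", "first", "only" and "open" are said of these compounds alone.

Measured so far:
Compound 1 `COc1ccc(F)cc1N1C(=O)CSC1c1cccc(C(=O)NCCCCc2ccccc2)c1`: 8.8 nM
Compound 2 `O=C(NCCCCc1ccccc1)c1cccc(C2SCC(=O)N2c2ccccc2)c1`: 15.9 nM
Compound 3 `O=C(NCCCCc1ccccc1)c1cccc(C2SCC(=O)N2c2cccc(-c3c[nH]nn3)c2)c1`: 110 nM

In a functional assay on HOS-TE85 cells (Homo sapiens) for inhibition, read by CCK-8 assay, with a stated time of 72 h (a higher number here means a weaker inhibitor, a lower number a stronger inhibitor), compound 3 has the highest of the three numbers, 110 nM, which makes it the weakest inhibitor here. Compound 4 `O=C(NCCCCc1ccccc1)c1cccc(C2SCC(=O)N2c2ccccn2)c1` differs from it in one place: a group of 6 heavy atoms (5 carbon, 1 nitrogen; one six-membered aromatic ring with 1 hetero atom) in place of a group of 11 heavy atoms (8 carbon, 3 nitrogen; one five-membered aromatic ring with 3 hetero atoms, one six-membered aromatic ring of carbon only), on an amide-type nitrogen in a ring. Adding 1H-1,2,3-triazol-4-yl in place of hydrogen on an aromatic carbon gave a 6.9-fold higher number from compound 2 to compound 3 (0.84 log units; beyond the scatter). Changing the whole group on that nitrogen gave a 13-fold higher number from compound 1 to compound 3 (1.10 log units; beyond the scatter), whereas the swap behind a 1.8-fold higher number from compound 1 to compound 2 (0.26 log units; within the scatter) stayed within the scatter. Among the compounds with values here, compound 4 lacks the triazole, so a lower number is expected, although no measured compound carries pyridin-2-yl. The expected change is a 3.7-fold lower number from compound 3 to compound 4 (0.56 log units; beyond the scatter). For compound 4 the estimated value is 30 nM, with an expected range of 10 nM to 90 nM.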

Compound 4, half-maximal inhibitory concentration: 19.7 nM
Beside the measured number, compound 4's estimate is 1.5-fold (0.18 log units) above it; measured number inside the range.
By their numbers in this assay, from the lowest: compounds 1, 2 and 4 (each within the scatter of the next, the first and the last beyond it); then compound 3.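

Putting a ring nitrogen into the group on the amide-type nitrogen, as pyridin-2-yl in place of phenyl, changes the number only within the scatter (a 1.2-fold higher number from compound 2 to compound 4 (0.09 log units; within the scatter)). Pyridin-2-yl in place of the triazole-bearing group removes much of the loss seen with compound 3 (a 5.6-fold lower number from compound 3 to compound 4 (0.75 log units; beyond the scatter)), although the 5-fluoro-2-methoxyphenyl group still gives a lower number (a 2.2-fold higher number from compound 1 to compound 4 (0.35 log units; beyond the scatter)). No measurements explain these shifts. The compounds shown do not reveal whether pyridin-3-yl or pyridin-4-yl would behave like pyridin-2-yl. They also leave open whether methoxy or fluorine alone on the phenyl ring matches compound 1, and how an amine or carboxylic acid there would fare.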